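Swapping cyclobutyl for isopentyl on an aromatic nitrogen

This account rests on a few compounds, and the source may have more. Where it says the series, first, only, none or still open, it means among the compounds named here.

Of the compounds shown here, three sharing one core have been measured so far in an ADME assay on a cell-free system (plasma, Rattus norvegicus) for metabolic stability, read by LC-MS, with a stated time of 1 h, at 37 degrees C, tested at 100 uM (a higher number here means that more of the compound is left, a lower number that less of the compound is left), and all of them hold up well. Compound 1 (`Cn1sc2cc(OCc3cccc(-c4ccc(Cl)c(C(=O)O)c4)c3)ccc2c1=O`) keeps 100% of its starting amount and compound 2 (`O=C(O)c1cc(-c2cccc(COc3ccc4c(=O)n(CC5CC5)sc4c3)c2)ccc1Cl`) keeps 100% of its starting amount. Compound 3 (`O=C(O)c1cc(-c2cccc(COc3ccc4c(=O)n(C5CCC5)sc4c3)c2)ccc1Cl`) keeps 91% of its starting amount, which lies within the scatter of both others, so these numbers do not rank the three.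

Compound 4 (`CC(C)CCn1sc2cc(OCc3cccc(-c4ccc(Cl)c(C(=O)O)c4)c3)ccc2c1=O`) differs from compound 3 in one place, on an aromatic nitrogen of a five-membered aromatic ring with 1 nitrogen and 1 sulfur (isopentyl in place of cyclobutyl on an aromatic nitrogen). The measured steps all alter the group on that same nitrogen. Adding cyclopropyl gave no change at the digits printed from compound 1 to compound 2 (within the scatter) and cyclobutyl in place of methyl gave a number 9 percentage points lower from compound 1 to compound 3 (within the scatter) while cyclobutyl in place of cyclopropylmethyl gave a number 9 percentage points lower from compound 2 to compound 3 (within the scatter) in turn. Isopentyl itself has not been measured on this nitrogen, so some uncertainty remains. Even so, no step beyond the scatter is expected in this assay in either direction. The expected size of the step is a number 4 percentage points higher from compound 3 to compound 4 (within the scatter) by this estimate. For compound 4 the expected value is 95% with an estimated range from 82% to 100% overall.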

Compound 4, percent of the compound remaining: 91%
Estimate against measurement, compound 4: 4 percentage points above, and the stated range covers the measured number.
By their numbers in this assay, from the lowest: compounds 3, 4, 1 and 2 (each within the scatter of the next).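

In this assay, isopentyl in place of cyclobutyl on the aromatic nitrogen gives no change at the digits printed from compound 3 to compound 4 (within the scatter), so an open, branched chain with no ring behaves here like the four-membered ring it replaces. The comparisons with the other two compounds agree: isobutyl in place of cyclopropyl on the saturated chain carbon bound to the aromatic nitrogen gives a number 9 percentage points lower from compound 2 to compound 4 (within the scatter), and isobutyl in place of hydrogen on that carbon gives a number 9 percentage points lower from compound 1 to compound 4 (within the scatter). Across methyl, cyclopropylmethyl, cyclobutyl and isopentyl, then, every step on this nitrogen stays within the scatter, and none of the four groups can be separated from the others by this read-out.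

Nothing available offers an explanation for these numbers. From the compounds shown here alone, it remains open whether this tolerance extends to a group of a different kind on the same nitrogen, such as a chain ending in an amine or a carboxylic acid, or a much longer alkyl chain, any of which might reveal a real difference in this assay.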